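The source may hold more compounds than are shown below. What is called first, only, known or untested is meant among the compounds shown, and "the series" means these compounds.

Compound 3 `C[C@H](NC(=O)c1c(C2CCCCC2)nnn1Cc1ccc(C(F)(F)F)cc1)c1ccc(C(=O)O)cc1` gives 161 nM in a functional assay on CHO cells for antagonist activity at prostaglandin E2 receptor EP4 subtype (Homo sapiens), read by calcium flux, with a stated time of 15 min; on this read-out higher numbers stand for weaker inhibition and lower numbers for stronger inhibition. Compound 1 `C[C@H](NC(=O)c1c(C(F)(F)F)nnn1Cc1ccc(C(F)(F)F)cc1)c1ccc(C(=O)O)cc1` gives 225 nM in this assay, and the two sit within the scatter of each other: a 1.4-fold lower number from compound 1 to compound 3 (0.15 log units; within the scatter). Compound 2 `Cc1nnn(Cc2ccc(C(F)(F)F)cc2)c1C(=O)N[C@@H](C)c1ccc(C(=O)O)cc1` gives > 10000 nM in this assay, which is a limit of the assay and not a number; see (the limit of > 10000 nM in this assay, at which 1 of the 3 values shown sits). The steps to and from that limit are large: an at least 44-fold higher number from compound 1 to compound 2 (1.64 log units; beyond the scatter) and an at least 62-fold lower number from compound 2 to compound 3 (1.79 log units; beyond the scatter).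

Compound 4 `Cc1ccc(-c2nnn(Cc3ccc(C(F)(F)F)cc3)c2C(=O)N[C@@H](C)c2ccc(C(=O)O)cc2)s1` has not been measured. The change from compound 3 is 5-methylthiophen-2-yl in place of cyclohexyl on an aromatic carbon. Among the compounds with values here, two measured steps bear on this position. The step of a 1.4-fold lower number from compound 1 to compound 3 (0.15 log units; within the scatter) shows that cyclohexyl and trifluoromethyl give numbers within the scatter, whereas an at least 62-fold lower number from compound 2 to compound 3 (1.79 log units; beyond the scatter) shows that methyl gives only a limit. The entering 5-methylthiophen-2-yl is, like cyclohexyl, a six-heavy-atom ring, so no step beyond the scatter is expected: a 1.2-fold higher number from compound 3 to compound 4 (0.09 log units; within the scatter). Compound 4 is therefore estimated at 200 nM in this assay, between 60 nM and 700 nM.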

Compound 4, half-maximal inhibitory concentration: 4.6 nM
Compound 4: middle estimate off by 43-fold (1.64 log units), on the high side, outside the stated range (below it).
By their numbers in this assay, from the lowest: compound 4; then compounds 3 and 1 (each within the scatter of the next). At a limit, above all of these: compound 2.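

At this position, cyclohexyl and 5-methylthiophen-2-yl have the same heavy-atom count but do not give equivalent numbers in this assay (a 35-fold lower number from compound 3 to compound 4 (1.54 log units; beyond the scatter)), so that count alone does not set the result. 5-Methylthiophen-2-yl also separates from trifluoromethyl (a 49-fold lower number from compound 1 to compound 4 (1.69 log units; beyond the scatter)), although cyclohexyl and trifluoromethyl had remained within the scatter of each other, so the position distinguishes groups that previously looked equivalent. The comparison with methyl gives only a bound (an at least 2100-fold lower number from compound 2 to compound 4 (3.33 log units; beyond the scatter)), as its starting value is a limit of the assay and not a number: the limit of > 10000 nM in this assay, at which 1 of the 4 values shown sits.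

The compounds shown do not separate the contributions of the ring sulfur, the aromatic five-membered ring and its methyl; unsubstituted thiophen-2-yl, furan-2-yl and phenyl would address this. As far as these compounds go, it also remains open whether the step holds when the 4-(trifluoromethyl)benzyl group is replaced by plain benzyl.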